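This account rests on a few compounds, and the source may have more. Where it says the series, first, only, none or still open, it means among the compounds named here.

Of the compounds shown here, two share one core and have been measured in a functional assay on HL-60 cells (Homo sapiens) for cytotoxicity, with a stated time of 48 h; on this read-out lower numbers stand for higher toxicity in this test and higher numbers for lower toxicity in this test. Compound 1 `COc1ccc(/C=C/C(=O)c2c(C)[n+]([O-])c3ccccc3[n+]2[O-])cc1` gives 16000 nM in this assay. Compound 2 `COc1ccc(/C=C/C(=O)c2c(C)[n+]([O-])c3ccccc3[n+]2[O-])cc1OC` carries one more methoxy group and gives 14000 nM in this assay. Along that change the number moved by a 1.1-fold lower number from compound 1 to compound 2 (0.06 log units; within the scatter). Within the data shown here, compound 2 therefore stands within the scatter of compound 1, the only other compound measured, and no order between the two can be read from these numbers.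

Compound 3 `COc1cc(/C=C/C(=O)c2c(C)[n+]([O-])c3ccccc3[n+]2[O-])cc(OC)c1OC` has not yet been measured. It differs from compound 2 in one place: methoxy in place of hydrogen on an aromatic carbon. Among the measured compounds shown here, the only measured step that bears on this change is the one methoxy addition already seen, a 1.1-fold lower number from compound 1 to compound 2 (0.06 log units; within the scatter), which stayed within the scatter. Adding a further methoxy group to the same ring is therefore expected to shift the number in this assay by no more than the scatter, with no clear direction. The expected step is a 1.2-fold lower number from compound 2 to compound 3 (0.07 log units; within the scatter). Compound 3 is thus estimated at 12000 nM in this assay, with a range from 5000 nM to 30000 nM.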

Compound 3, half-maximal cytotoxic concentration: 1900 nM
Compound 3: the middle estimate sits 6.3-fold (0.80 log units) above what was measured; measured number outside the range, below it.
By their numbers in this assay, from the lowest: compound 3; then compounds 2 and 1 (each within the scatter of the next).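

The same swap of hydrogen for methoxy behaves differently here: in this assay the earlier addition stayed within the scatter (a 1.1-fold lower number from compound 1 to compound 2 (0.06 log units; within the scatter)), whereas this one, ortho to a methoxy group and meta to another, gives a step beyond it (a 7.4-fold lower number from compound 2 to compound 3 (0.87 log units; beyond the scatter)). Among these compounds, then, the size of a methoxy step does not carry over from one addition to the next, so the first small step gave no safe guide to the second. Nothing measured here explains the larger step, and no supporting data bear on its cause.

The compounds shown leave open whether this position matters in its own right or whether the step depends on the methoxy groups already on the ring, which a compound carrying the new methoxy group without its ortho neighbour could help separate. They also leave open whether another group in the same place, such as a hydroxyl, a fluorine or an ethoxy, would give a step of similar size.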